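Swapping phenyl for cyclohexyl on a shared core

The source may report more compounds than this note shows. Statements on the series, on what has been measured and on what is new or still open speak of the compounds shown alone.

Measured so far:
compound 1, `O=C(CSc1nnc2scc(-c3ccc(Cl)cc3)n12)c1ccc(Br)cc1`, which in an assay on cells for inhibition of Indoleamine 2,3-dioxygenase 1 (Homo sapiens) (a lower number here means a stronger inhibitor, a higher number a weaker inhibitor), gives 339 nM
compound 2, `CCCS(=O)(=O)NCc1cnc2scc(-c3ccc(Br)cc3)n12`, which in this assay gives 1070 nM
compound 3, `OC(c1ccccc1)c1cnc2scc(-c3ccc(Br)cc3)n12`, which in this assay gives 1090 nM

Compound 3 shows the highest number of the three in this assay, which here means the weakest inhibition among them. The nearest of the others is compound 2, whose value of 1070 nM lies within the usual scatter of compound 3, so these two cannot be told apart on the numbers alone. Compound 1, at 339 nM, stands clearly beyond the scatter on the stronger side.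

The next compound, compound 4, `OC(c1cnc2scc(-c3ccc(Br)cc3)n12)C1CCCCC1`, keeps the core and the carbinol group of compound 3 and changes only one thing: cyclohexyl in place of phenyl on a saturated chain carbon bound to an aromatic carbon and an oxygen on a saturated carbon. The saturated ring replaces the aromatic one at the same spot, with the same number of carbon atoms and no change in donors, acceptors or charge.

Among the compounds with values here, none of the measured pairs differ at this spot, so there is no measured step to lean on. Given that, the step of a 1.3-fold higher number from compound 3 to compound 4 (0.11 log units; within the scatter) is expected to stay within the scatter or to weaken inhibition only slightly. For compound 4 in this assay the estimate is 1400 nM, with a likely range from 500 nM to 4000 nM.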

Compound 4, half-maximal inhibitory concentration: 1280 nM
The estimate for compound 4 lay 1.1-fold (0.04 log units) above the measured number, and the stated range covers the measured number.
By their numbers in this assay, from the lowest: compound 1; then compounds 2, 3 and 4 (each within the scatter of the next).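

In this assay the swap of phenyl for cyclohexyl on this saturated chain carbon gives a 1.2-fold higher number from compound 3 to compound 4 (0.07 log units; within the scatter) and so leaves the two compounds indistinguishable on the numbers. Within the data shown here, this is the first pair that differs in one place, and it shows that, on this core and in this assay, whether the ring at this spot is aromatic or non-aromatic makes no difference that the measurement can detect. Nothing available explains why the two rings read alike, so the result stands as an observation with no reason attached.

Phenyl and cyclohexyl are both six-membered rings of carbon only, so the compounds shown do not tell whether a much smaller methyl group, a longer chain, or a ring carrying an amine or a carboxylic acid would read the same at this spot. Also open, from the compounds shown here alone, is whether the hydroxyl on this carbon matters to the number, a question that a ketone carbonyl at the same carbon could begin to answer.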